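The source may hold more compounds than are shown below. What is called first, only, known or untested is meant among the compounds shown, and "the series" means these compounds.

In a physicochemical assay for lipophilicity (a higher number here means a more lipophilic compound, a lower number a more polar compound), the three measured compounds spread across a wide range. Compound 1, `CC(/C=C/CC(C)CCCC(C)C)=C\C(=O)Oc1ccccc1`, gives 7.67, the highest of the three. Compound 2, `C=CCOC(=O)/C=C(C)/C=C/CC(C)CCCC(C)(C)OC`, gives 5.53, the lowest. Compound 3, `CCOC(=O)/C=C(C)/C=C/CC(C)CCCC(C)(C)OCC`, gives 6.08, the second highest: its nearest neighbour is compound 2, lower by a gap beyond the scatter, and compound 1 sits further away, higher by a gap also beyond the scatter.

The step under consideration leads from compound 3 to compound 4, `CCOC(=O)/C=C(C)/C=C/CC(C)CCC(=O)C(C)C`, which has not yet been measured in this assay. The change is isopropylcarbonyl in place of 2-ethoxy-2-methylpropyl on a saturated chain carbon, four bonds along the chain from a double-bonded chain carbon. Among the measured compounds shown here, the fragment that leaves counts 7 heavy atoms, the one that enters only 5, and the ether oxygen gives way to a carbonyl; no measured pair in this set makes a comparable change, so the size of the step can only be inferred from the structures.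

For compound 4 the expected step is a number 1.28 log units lower from compound 3 to compound 4 (beyond the scatter), a drop beyond the scatter. Starting from compound 3 at 6.08, compound 4 is estimated at 4.8, with a range from 4.1 to 5.5.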

Compound 4, partition coefficient: 4.3
For compound 4 the middle estimate is 0.50 log units above the measured one; the measured number falls inside the stated range.
By their numbers in this assay, from the lowest: compound 4; then compound 2; then compound 3; then compound 1.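

In this assay, putting isopropylcarbonyl in place of 2-ethoxy-2-methylpropyl on this saturated chain carbon gives a number 1.78 log units lower from compound 3 to compound 4 (beyond the scatter), a large step and the first that can be read in this set. It shows that the number responds strongly to a change at this position. The step comes with no change in the counts of hydrogen-bond donors and acceptors, while the entering group has fewer heavy atoms and carries a double bond. No supporting data bear on what lies behind the size of this step.

The single swap alters size and oxygen environment together, so the compounds shown do not separate these two changes. From the compounds shown here alone, whether an amine or a longer chain at this position would move the number as far also remains open.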